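Alkylation on the core nitrogen: methyl to ethyl

The source may report more compounds than this note shows. Statements on the series, on what has been measured and on what is new or still open speak of the compounds shown alone.

Compound 1 `COc1ccc(-c2cc3c(cn2)[nH]c(=O)n3-c2cc(OC)c(OC)c(OC)c2)cc1O`: 630 nM
Compound 2 `COc1ccc(-c2cc3c(cn2)n(C)c(=O)n3-c2cc(OC)c(OC)c(OC)c2)cc1O`: 3520 nM

In a functional assay on A549 cells (Homo sapiens) for antiproliferative activity, read by MTT assay, with a stated time of 48 h (a higher number here means a weaker inhibitor, a lower number a stronger inhibitor), compound 2 gives the highest of the two numbers, its nearest neighbour being compound 1 with 630 nM. Going by the values given here, the only measured step is a 5.6-fold higher number from compound 1 to compound 2 (0.75 log units; beyond the scatter). Compound 3 `CCn1c(=O)n(-c2cc(OC)c(OC)c(OC)c2)c2cc(-c3ccc(OC)c(O)c3)ncc21` differs from compound 2 by methyl in place of hydrogen on a saturated chain carbon bound to an aromatic nitrogen. That step bears on the same nitrogen, and the measured step from compound 1 to compound 2 was a weakening of modest size, so a further small step in the same direction, or none beyond the scatter, is expected for compound 3: a 1.6-fold higher number from compound 2 to compound 3 (0.19 log units; within the scatter). Compound 3 is therefore estimated at 5500 nM, within 2000 nM to 15000 nM.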

Compound 3, half-maximal inhibitory concentration: > 20000 nM
Compound 3: only a limit was reported; the forecaster's own chance of this, stated with the estimate: 5%; middle value at least 3.6-fold (0.56 log units) away from the limit.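

Compound 3 is reported only as a limit, not as a number: the limit of > 20000 nM in this assay, at which 1 of the 3 values shown sits. Going from methyl to ethyl on this nitrogen is therefore no small change, giving an at least 5.6-fold higher number from compound 2 to compound 3 (0.75 log units; beyond the scatter). Across the three compounds, each added carbon on this nitrogen weakens the result, and ethyl in place of hydrogen gives an at least 31-fold higher number from compound 1 to compound 3 (1.50 log units; beyond the scatter).

From the compounds shown here alone, the true size of the loss for compound 3 stays open. So does whether a longer chain, or an amine or carboxylic acid at the end of the chain, would follow the same trend.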